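The compounds below may be only part of what the source reports. "The series", "measured", "known", "first", "only" and "open" are said of these compounds alone.

In an ADME assay on microsomes from liver (Homo sapiens) for metabolic stability, read by LC-MS, using NADPH, with stated times of 5 min and 30 min, tested at 1 uM (a lower number here means slower removal, a higher number faster removal of the compound), compound 2 (`Cc1nc(CO)ccc1-c1cnc(NCc2c(F)ccc3c2CCO3)c2cn[nH]c(=O)c12`) gives 11 mL.min-1.g-1. Compound 1 (`Cc1nccn1-c1cnc(NCc2c(F)ccc3c2CCO3)c2cn[nH]c(=O)c12`) gives 8 mL.min-1.g-1, and the two numbers cannot be told apart: the step, a 1.4-fold higher number from compound 1 to compound 2 (0.14 log units; within the scatter), lies within the scatter. Compound 3 (`COCCC(=O)Nc1cnc(NCc2c(F)ccc3c2CCO3)n2cnnc12`) gives only a limit of the assay, < 3 mL.min-1.g-1.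

Compound 4 (`CC(=O)N1CCC(c2cnc(NCc3c(F)ccc4c3CCO4)c3cn[nH]c(=O)c23)CC1`) keeps the core of compound 2 but carries 1-acetylpiperidin-4-yl in place of 6-(hydroxymethyl)-2-methylpyridin-3-yl on an aromatic carbon. A six-membered aromatic ring thus gives way to a six-membered non-aromatic ring. Within the data shown here, only one measured step bears on this change, the exchange of groups on that same aromatic carbon between compound 1 and compound 2, a 1.4-fold higher number from compound 1 to compound 2 (0.14 log units; within the scatter). Among the measured compounds shown here, that single small step is thin evidence, and no compound measured so far carries a non-aromatic ring there. No step beyond the scatter is therefore expected in this assay, though the uncertainty is wide. The estimate amounts to an expected 1.1-fold lower number from compound 2 to compound 4 (0.04 log units; within the scatter). For compound 4 the estimated value is 10 mL.min-1.g-1, with an expected range from 4 mL.min-1.g-1 to 25 mL.min-1.g-1.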

Compound 4, intrinsic clearance in microsomes: 207 mL.min-1.g-1
Beside the measured number, compound 4's estimate is 21-fold (1.32 log units) below it, and the stated range ends below it.
By their numbers in this assay, from the lowest: compounds 1 and 2 (each within the scatter of the next); then compound 4. At a limit, below all of these: compound 3.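

In this assay the group on this aromatic carbon proves able to change the result strongly: 1-acetylpiperidin-4-yl gives a 19-fold higher number from compound 2 to compound 4 (1.27 log units; beyond the scatter), and in place of 2-methyl-1H-imidazol-1-yl the same group gives a 26-fold higher number from compound 1 to compound 4 (1.41 log units; beyond the scatter). The exchange of one aromatic group for another had stayed within the scatter, whereas this first six-membered non-aromatic ring at the position brings much faster removal, even though the group that leaves compound 2 has the same number of heavy atoms. Nothing measured here explains this rise.

On these data alone, it remains open whether the non-aromatic ring or the acetyl group on its nitrogen accounts for the step. A piperidin-4-yl with a free amine, or a cyclohexyl ring, on the same carbon would help to separate the two.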